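The compounds below may be only part of what the source reports. "The series", "measured", "known", "first", "only" and "open" are said of these compounds alone.

Measured in a functional assay on a cell-free system (plasma, Oryctolagus cuniculus) for inhibition, with stated times of 5 min, 1 min and 6 min; on this read-out lower numbers stand for stronger inhibition and higher numbers for weaker inhibition:
compound 1 `CCOC(=O)c1c(C)nc(-c2ccccc2C#N)n1OC` gives 14900 nM
compound 2 `C=CCOn1c(-c2cccc(C#N)c2)nc(C)c1C(=O)OCC` gives 5860 nM
compound 3 `CCOC(=O)c1c(C)nc(-c2cccc(C#N)c2)n1OCCCO` gives 11400 nM

In this assay the number of compound 3 sits between those of compound 1 and compound 2, and both of those lie within the scatter of it, so the three measured compounds are not separated.

Compound 4 `CCOC(=O)c1c(C)nc(-c2cccc(C#N)c2)n1OCc1ccc(C(=O)OC)cc1` differs from compound 3 by 4-(methoxycarbonyl)phenyl in place of 2-hydroxyethyl on a saturated chain carbon bound to an oxygen on an aromatic ring. Among the measured compounds shown here, the only measured step at this place is a 1.9-fold higher number from compound 2 to compound 3 (0.29 log units; within the scatter), which was within the scatter. For the measured compounds named here, no measured compound carries an aromatic ring at this place, so nothing bears directly on the entering group. The expectation is therefore no step beyond the scatter, a 1.1-fold lower number from compound 3 to compound 4 (0.06 log units; within the scatter). Compound 4 is estimated at 10000 nM, with a range from 3000 nM to 35000 nM.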

Compound 4, half-maximal inhibitory concentration: 9470 nM
Estimate against measurement, compound 4: 1.1-fold (0.02 log units) above, and the stated range covers the measured number.
By their numbers in this assay, from the lowest: compounds 2, 4, 3 and 1 (each within the scatter of the next, the first and the last beyond it).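

In this assay, an aromatic ring at this place, on a saturated chain carbon bound to an oxygen on an aromatic ring, leaves the number within the scatter. 4-(methoxycarbonyl)phenyl in place of 2-hydroxyethyl gives a 1.2-fold lower number from compound 3 to compound 4 (0.08 log units; within the scatter) and in place of vinyl gives a 1.6-fold higher number from compound 2 to compound 4 (0.21 log units; within the scatter). The position therefore takes a group of 10 heavy atoms with no step beyond the scatter, and no supporting evidence bears on this result.

Going by these compounds, whether an amine, a carboxylic acid or a longer chain at this place would give a step beyond the scatter remains open. Also open, on these data alone, is whether a phenyl group without the methoxycarbonyl would read the same.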